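Thiourea series at the vanilloid receptor: compound 3 to compound 4

The source may hold more compounds than are shown below. What is called first, only, known or untested is meant among the compounds shown, and "the series" means these compounds.

The shared core of compound 3 `CC(C)S(=O)(=O)Nc1ccc(C/N=C(\S)NCc2ccc(C(C)(C)C)cc2)cc1` is also present in compound 1 `COc1cc(C/N=C(\S)NCc2ccc(C(C)(C)C)cc2)ccc1OS(C)(=O)=O` and compound 2 `CC(C)(C)c1ccc(C/N=C(\S)NCc2ccc(C(F)(F)F)cc2)cc1`. In a functional assay for antagonist activity at Vanilloid receptor (Rattus norvegicus) (on this read-out lower numbers stand for stronger inhibition and higher numbers for weaker inhibition), compound 1 gives 300 nM, compound 2 gives 12400 nM and compound 3 gives 3800 nM. Compound 3 thus stands second highest of the three numbers, beyond the scatter from both neighbours: compound 2 is higher, compound 1 lower.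

Compound 4 `CN(c1ccc(C/N=C(\S)NCc2ccc(C(C)(C)C)cc2)cc1)S(C)(=O)=O` is not yet measured. It differs from compound 3 in one place: methyl(methylsulfonyl)amino in place of (isopropylsulfonyl)amino on an aromatic carbon. Within the data shown here, no single-point step between measured compounds exists in this set, so the size of the change cannot be read from measured pairs; the numbers of compound 1 and compound 2 only show the range that para substitution on this ring has spanned so far.

The expectation is a small step from compound 3 to compound 4, a 1.6-fold higher number from compound 3 to compound 4 (0.20 log units; within the scatter), towards a weaker number, not clearly beyond the scatter. Compound 4 is estimated at 6000 nM, with a range from 1500 nM to 25000 nM.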

Compound 4, half-maximal inhibitory concentration: 2500 nM
Estimate against measurement, compound 4: 2.4-fold (0.38 log units) above; the range from low to high includes it.
By their numbers in this assay, from the lowest: compound 1; then compounds 4 and 3 (each within the scatter of the next); then compound 2.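

In this assay, among these compounds, the first single-point step is a 1.5-fold lower number from compound 3 to compound 4 (0.18 log units; within the scatter), so at this place, para to a large group, methyl(methylsulfonyl)amino and (isopropylsulfonyl)amino cannot be told apart. The hydrogen-bond donor of (isopropylsulfonyl)amino is absent from methyl(methylsulfonyl)amino, yet the read-out does not separate the two groups, although the alkyl group on sulfur changes in the same step and the two changes could offset each other. Nothing measured here explains the flat step.

The compounds shown do not separate the methyl on nitrogen from the change of alkyl group on sulfur; plain (methylsulfonyl)amino would divide the step into those two parts. From the compounds shown here alone, whether this place tolerates groups other than sulfonyl-bearing ones, such as a carboxylic acid or an amine, also stays open.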